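Swapping sulfur for selenium on a second core

A few compounds are considered here, and "the series" means these few. Any claim that something is new, unique, unknown or untested is made for them only; others in the source may bear on it.

Compound 1 `C[Se]/C(=N\C(=O)c1cc2ccccc2s1)NC(=O)c1cc2ccccc2s1`: 490 nM
Compound 2 `CS/C(=N\C(=O)c1cc2ccccc2s1)NC(=O)c1cc2ccccc2s1`: 20 nM
Compound 3 `CS/C(=N\C(=O)c1cc(-c2ccccc2)nc2ccccc12)NC(=O)c1cc(-c2ccccc2)nc2ccccc12`: 40 nM

These three compounds were tested in an ADME assay on MCF-10A cells (Homo sapiens) for cytotoxicity, read by MTT assay, with a stated time of 72 h; on this read-out lower numbers stand for stronger inhibition of growth and higher numbers for weaker inhibition of growth. Compound 2 and compound 1 share a core and differ only by a group of 2 heavy atoms (1 carbon, 1 selenium; no ring) in place of a group of 2 heavy atoms (1 carbon, 1 sulfur; no ring), on a carbon with a double bond to nitrogen; this change gave a 25-fold higher number from compound 2 to compound 1 (1.39 log units; beyond the scatter). Compound 3 carries another core; how its core differs from that of compound 2 is not broken down here, and in this assay compound 3 and compound 2 give values within the usual scatter of each other.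

Compound 4 `C[Se]/C(=N\C(=O)c1cc(-c2ccccc2)nc2ccccc12)NC(=O)c1cc(-c2ccccc2)nc2ccccc12` has not yet been measured. It differs from compound 3 by a group of 2 heavy atoms (1 carbon, 1 selenium; no ring) in place of a group of 2 heavy atoms (1 carbon, 1 sulfur; no ring), on a carbon with a double bond to nitrogen, the same change as that from compound 2 to compound 1. For compound 4 a step of about a 25-fold higher number from compound 3 to compound 4 (1.40 log units; beyond the scatter) is expected, because the earlier step of a 25-fold higher number from compound 2 to compound 1 (1.39 log units; beyond the scatter) was large. Compound 4 is therefore estimated at 1000 nM, with a likely range from 300 nM to 3500 nM.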

Compound 4, concentration for 50% growth inhibition: 710 nM
Compound 4: the middle estimate sits 1.4-fold (0.15 log units) above what was measured; the range from low to high includes it.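

On the second core, replacing methylsulfanyl with the matching selenium group gave an 18-fold higher number from compound 3 to compound 4 (1.25 log units; beyond the scatter) in this assay, so growth inhibition again became much weaker. The two cores agree on the size of this step: the same change on two cores in this assay, a 25-fold higher number (1.39 log units; beyond the scatter) from compound 2 to compound 1 and an 18-fold higher number (1.25 log units; beyond the scatter) from compound 3 to compound 4, 1.4-fold (0.14 log units) apart, within the scatter of two such steps. This shows that the change carried over between these two cores in this one assay, but two cores cannot show that it would do so on others, and the numbers do not explain why it happens.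

The compounds shown leave open whether a longer chain, such as ethyl, on the sulfur or selenium would give a similar result. They also leave open how an amine would compare on that same carbon.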